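Swapping 3-methylphenyl for a (4-methylphenyl)carbonyl group

This account rests on a few compounds, and the source may have more. Where it says the series, first, only, none or still open, it means among the compounds named here.

In a functional assay on OVCAR-3 cells (Homo sapiens) for antiproliferative activity, read by MTT assay, with a stated time of 24 h (a higher number here means a weaker inhibitor, a lower number a stronger inhibitor), compound 1 (`Cc1cccc(NNC(=O)c2ccc(NS(=O)(=O)c3cnc(O)nc3O)cc2)c1`) gives > 20000 nM as a limit of the assay, not a number. Compound 2 (`Cc1ccccc1NNC(=O)c1cccc(NS(=O)(=O)c2cnc(O)nc2O)c1`) gives > 20000 nM as a limit too. Compound 3 (`O=C(NNc1ccccc1Cl)c1ccccc1NS(=O)(=O)c1cnc(O)nc1O`) gives 14100 nM as an actual number. Compound 1 therefore sits at the limit of > 20000 nM in this assay, at which 2 of the 3 values shown sit, and has no exact value of its own.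

Compound 4 (`Cc1ccc(C(=O)NNC(=O)c2ccc(NS(=O)(=O)c3cnc(O)nc3O)cc2)cc1`) differs from compound 1 in one place: (4-methylphenyl)carbonyl stands in place of 3-methylphenyl on an amine nitrogen ((4-methylphenyl)carbonyl in place of 3-methylphenyl on an amine nitrogen). Within the data shown here, no pair of measured compounds shows this change, so the size of the step can only be judged loosely. I expect no step beyond the usual scatter in this assay and no clear direction, and the estimated step of a number no higher from compound 1 to compound 4 (the limit leaves the size open) is to be read in that light. For compound 4 the estimate is 20000 nM with an expected range from 8000 nM to 40000 nM and a good chance of only a limit.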

Compound 4, half-maximal inhibitory concentration: > 20000 nM
Compound 4: no number, only a limit; the forecaster's own chance of this, stated with the estimate: 60%; the middle value lies on the limit itself.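

No step can be read from compound 1 to compound 4, since each gives only a limit of the assay and not a number, and both stand at the same one: the limit of > 20000 nM in this assay, at which 3 of the 4 values shown sit.

The compounds shown leave open how far either lies past that limit, and whether (4-methylphenyl)carbonyl in place of 3-methylphenyl changes the result in this assay at all.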